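Replacing 4-methylpiperazin-1-yl with hydroxy on the side chain

The compounds below may be only part of what the source reports. "The series", "measured", "known", "first", "only" and "open" are said of these compounds alone.

In a functional assay on K562 cells (Homo sapiens) for antiproliferative activity, read by MTT assay, with a stated time of 48 h (a lower number here means a stronger inhibitor, a higher number a weaker inhibitor), compound 1 `CN(C)CCn1c(N)c(-c2nc3ccccc3[nH]2)c2nc(C#N)c(C#N)nc21` gives 6340 nM. In the same test, compound 2 `CN1CCN(CCn2c(N)c(-c3nc4ccccc4[nH]3)c3nc(C#N)c(C#N)nc32)CC1` gives 6550 nM. Among the compounds with values here, these two numbers lie within the scatter of each other, so compound 2 stands level with the only other measured compound. Compound 3 `N#Cc1nc2c(-c3nc4ccccc4[nH]3)c(N)n(CCO)c2nc1C#N` keeps the shared core and differs from compound 2 at a single place: hydroxy in place of 4-methylpiperazin-1-yl on a saturated chain carbon, two bonds along the chain from an aromatic nitrogen. Hydroxy stands in place of 4-methylpiperazin-1-yl on a saturated chain carbon, two bonds along the chain from an aromatic nitrogen.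

Within the data shown here, only one measured step bears on this change: a 1.0-fold higher number from compound 1 to compound 2 (0.01 log units; within the scatter). It concerns the same place and stays within the scatter, but it only exchanges dimethylamino for 4-methylpiperazin-1-yl. It is therefore a limited guide to hydroxy. On this evidence, no shift beyond the scatter is expected in this assay, and no direction can be favoured. The estimated step is a 1.1-fold higher number from compound 2 to compound 3 (0.03 log units; within the scatter). Among the measured compounds shown here, no measured compound carries hydroxy at this place, and the range is kept wide. Compound 3 is estimated at 7000 nM, with an expected range from 2500 nM to 20000 nM.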

Compound 3, half-maximal inhibitory concentration: > 50000 nM
Compound 3 gave a limit, no number; the forecaster's own chance of this, stated with the estimate: 10%; middle value at least 7.1-fold (0.85 log units) away from the limit.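

In this assay compound 3 gave only a limit and not a number: the limit of > 50000 nM in this assay, at which 1 of the 3 values shown sits. Even so, the result shows that this place on the side chain is not indifferent to what it carries, as the earlier pair alone might have suggested: hydroxy in place of 4-methylpiperazin-1-yl gives an at least 7.6-fold higher number from compound 2 to compound 3 (0.88 log units; beyond the scatter), and hydroxy in place of dimethylamino gives an at least 7.8-fold higher number from compound 1 to compound 3 (0.89 log units; beyond the scatter). Exchanging one amine for the other on this saturated chain carbon changed nothing beyond the scatter, with a 1.0-fold higher number from compound 1 to compound 2 (0.01 log units; within the scatter), whereas replacing either amine with hydroxy produced a clear loss of antiproliferative activity.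

Going by these compounds, since only a limit is available, the full size of both new steps remains unknown. The compounds shown also leave open whether the amine nitrogen itself is what matters, since a primary amine, a morpholin-4-yl ring or a methoxy group at the same place could show whether such a group stays with the two amines or goes with hydroxy.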